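This account rests on a few compounds, and the source may have more. Where it says the series, first, only, none or still open, it means among the compounds named here.

Compound 1 `COC(=O)N[C@H](C(=O)NN(CCC[C@@](O)(Cc1ccccc1)C(=O)N[C@H]1c2ccccc2C[C@H]1O)Cc1ccc(Cl)cc1)C(C)(C)C` carries a chloro group on an aromatic carbon. In an ADME assay on MT4 cells (Homo sapiens) for cytotoxicity (a lower number here means that less compound is tolerated, a higher number that more compound is tolerated), compound 1 reaches only the limit of the assay, > 10000 nM. Compound 2 `COC(=O)N[C@H](C(=O)NN(CCC[C@@](O)(Cc1ccccc1)C(=O)N[C@H]1c2ccccc2C[C@H]1O)Cc1ccc(N(C)C)cc1)C(C)(C)C` has dimethylamino in place of chloro. In this assay compound 2 likewise gives only a limit, > 10000 nM. Compound 3 `COC(=O)N[C@H](C(=O)NN(CCC[C@@](O)(Cc1ccccc1)C(=O)N[C@H]1c2ccccc2C[C@H]1O)Cc1ccc(-c2csc(C)n2)cc1)C(C)(C)C` bears 2-methyl-1,3-thiazol-4-yl in place of chloro. In this assay compound 3 again gives only a limit, > 10000 nM. Compound 2 therefore stands where every measured compound stands, namely at the limit of > 10000 nM in this assay, at which 3 of the 3 values shown sit, and none of the three steps among these compounds can be sized: a step that the two limits leave unreadable from compound 1 to compound 2, a step that the two limits leave unreadable from compound 1 to compound 3 and a step that the two limits leave unreadable from compound 2 to compound 3 all lie between two limits.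

Compound 4 `COC(=O)N[C@H](C(=O)NN(CCC[C@@](O)(Cc1ccccc1)C(=O)N[C@H]1c2ccccc2C[C@H]1O)Cc1ccc(OCc2cnc(Cl)s2)cc1)C(C)(C)C` differs from compound 2 in one place: (2-chloro-1,3-thiazol-5-yl)methoxy in place of dimethylamino on an aromatic carbon. Since every measured change at this aromatic carbon left the read-out at the limit, compound 4 is expected to behave the same way, with a step that the limit leaves unreadable from compound 2 to compound 4 and an estimated half-maximal cytotoxic concentration of 15000 nM, between 7000 nM and 40000 nM.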

Compound 4, half-maximal cytotoxic concentration: > 10000 nM
Compound 4: no number, only a limit; the forecaster's own chance of this, stated with the estimate: 75%; the middle value is on the limit's open side.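

Compound 4 gives only a limit in this assay just as compound 1, compound 2 and compound 3 do, so none of its steps to them can be read. The compounds shown leave open how much of each compound is tolerated beyond that limit, and whether the group on this aromatic carbon changes it.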